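Benzyl for Cyclohexyl on a Second Imidazole-Bearing Core

The source may report more compounds than this note shows. Statements on the series, on what has been measured and on what is new or still open speak of the compounds shown alone.

Four compounds stand side by side here. Compound 1 `O=Cc1ccc(-c2cn3ccnc3c(-c3ccc4ncn(C5CCCCC5)c4c3)n2)cc1` carries a cyclohexyl group on an aromatic nitrogen; compound 2 `O=Cc1ccc(-c2cn3ccnc3c(-c3ccc4ncn(Cc5ccccc5)c4c3)n2)cc1` carries a benzyl group at the same place. Compound 3 `c1cn2cc(-c3ccc4c(c3)ncn4C3CCCCC3)nc(-c3ccc4ncn(C5CCCCC5)c4c3)c2n1` is built on a different core, and compound 4 `c1ccc(Cn2cnc3ccc(-c4nc(-c5ccc6c(c5)ncn6C5CCCCC5)cn5ccnc45)cc32)cc1` is its benzyl counterpart. The difference between the core of compound 1 and the core of compound 3 is not broken down here.

In a functional assay on M14 cells (Homo sapiens) for inhibition, read by sulforhodamine B assay, with a stated time of 48 h, tested at 10 uM (a lower number here means less inhibition, a higher number more inhibition at the concentration tested (going by the name of the read-out)), compound 1 gives 23%, and compound 2 gives 23%. The change between them is benzyl in place of cyclohexyl on an aromatic nitrogen, and the step it made, no change at the digits printed from compound 1 to compound 2 (within the scatter), shows no movement. Compound 3 gives 6.98% in this assay, the lowest of the three numbers, with both other compounds standing beyond the scatter above it.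

Compound 4 arises from compound 3 by the same change: benzyl in place of cyclohexyl on an aromatic nitrogen. Within the data shown here, since the one example of this change, from compound 1 to compound 2, left the read-out where it was, the same outcome is expected on the core of compound 3, and the expected step is a number 1 percentage points higher from compound 3 to compound 4 (within the scatter). That expectation rests on a single precedent, so it is held loosely. Compound 4 is therefore estimated to give 8% in this assay, with the likely range running from -2% to 20%.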

Compound 4, a percentage reported as inhibition, at one concentration (the size of the read-out at that concentration, not a potency): -4.44%
Beside the measured number, compound 4's estimate is 12.4 percentage points above it, outside the stated range (below it).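

On the core of compound 3, putting benzyl in place of cyclohexyl on an aromatic nitrogen gave, in this assay, a number 11.4 percentage points lower from compound 3 to compound 4 (beyond the scatter), while on the core of compound 1 the same change gave no change at the digits printed from compound 1 to compound 2 (within the scatter). Among these compounds, although only the second of these steps lies beyond the scatter, the two cannot be told apart when set side by side: the same change on two cores in this assay, no change at the digits printed (within the scatter) from compound 1 to compound 2 and a number 11.4 percentage points lower (beyond the scatter) from compound 3 to compound 4, 11.4 percentage points apart, within the scatter of two such steps The pairs therefore give no sound ground for saying that the core alters the outcome of this change, yet they do not establish that it carries over unaltered, since each core supplies only one pair and the read-out comes from a single concentration.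

The compounds shown leave open whether other groups on this aromatic nitrogen, such as a longer alkyl chain, an amine or a carboxylic acid, would produce steps that clearly differ between the two cores. They also leave open what happens when the remaining cyclohexyl of compound 4 is changed, and whether the same pairs would separate at another concentration or in a measure of potency rather than in a single percentage.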